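The source may hold more compounds than are shown below. What is called first, only, known or untested is meant among the compounds shown, and "the series" means these compounds.

Measured so far:
compound 1 `COc1ccccc1C(=O)NCCNc1cccc(NS(=O)(=O)c2cc(-c3cccc(C(=O)N(C)C)c3)ccc2OC)c1`, 50 nM
compound 2 `COc1ccc(-c2cccc(C(=O)N(C)C)c2)cc1S(=O)(=O)Nc1cccc(NCCNC(=O)c2ccccc2)c1`, > 10000 nM
compound 3 `COc1cccc(C(=O)NCCNc2cccc(NS(=O)(=O)c3cc(-c4cccc(C(=O)N(C)C)c4)ccc3OC)c2)c1`, 33 nM

In an assay on CHO-K1 cells for agonist activity at Orexin receptor type 2 (Homo sapiens), read by a luciferase reporter (a lower number here means that less compound is needed, a higher number that more compound is needed for the effect), compound 3 stands close to compound 1, since the step of a 1.5-fold lower number from compound 1 to compound 3 (0.18 log units; within the scatter) lies within the scatter. Compound 2 differs from compound 1 only by an at least 200-fold higher number from compound 1 to compound 2 (2.30 log units; beyond the scatter), and its value is a limit of the assay, not a number; it sits at the limit of > 10000 nM in this assay, at which 1 of the 3 values shown sits. Compound 4 `COc1ccc(C(=O)NCCNc2cccc(NS(=O)(=O)c3cc(-c4cccc(C(=O)N(C)C)c4)ccc3OC)c2)cc1` is not yet measured. It differs from compound 3 by 4-methoxyphenyl in place of 3-methoxyphenyl on a carbonyl carbon. For the measured compounds named here, the only measured step that bears on this change is the one from compound 1 to compound 3, where the methoxy group on the same ring was moved and gave a 1.5-fold lower number from compound 1 to compound 3 (0.18 log units; within the scatter), a step within the scatter. Moving the methoxy group once more is therefore expected to give a step that stays within the scatter, in no clear direction: a 1.2-fold higher number from compound 3 to compound 4 (0.08 log units; within the scatter). Compound 4 is expected to give about 40 nM in this assay, in the range from 15 nM to 120 nM.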

Compound 4, half-maximal effective concentration: 1050 nM
Estimate against measurement, compound 4: 26-fold (1.42 log units) below, and the stated range ends below it.
By their numbers in this assay, from the lowest: compounds 3 and 1 (each within the scatter of the next); then compound 4. At a limit, above all of these: compound 2.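

In this assay, where the methoxy group sits on this ring matters after all: there is a 32-fold higher number from compound 3 to compound 4 (1.50 log units; beyond the scatter), and likewise a 21-fold higher number from compound 1 to compound 4 (1.32 log units; beyond the scatter), so 4-methoxyphenyl on the carbonyl carbon stands apart from the 3-methoxyphenyl and 2-methoxyphenyl groups, which lie within the scatter of each other. Even in this less favourable place, having a methoxy group still counts for something, with an at least 9.5-fold lower number from compound 2 to compound 4 (0.97 log units; beyond the scatter). That step is only a bound, since the value of compound 2 is a limit of the assay and not a number: the limit of > 10000 nM in this assay, at which 1 of the 4 values shown sits.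

The compounds shown leave open whether the methoxy group itself is needed, or whether a methyl, a fluorine or a hydroxy group on the same ring would serve as well. They also give no cause for the gap between 4-methoxyphenyl and the other two groups.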